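Methyl on the Outer Phenyl Ring: Compound 4 Expected

A few compounds are considered here, and "the series" means these few. Any claim that something is new, unique, unknown or untested is made for them only; others in the source may bear on it.

Compound 1 `COc1cc2c(Oc3ccc(NC(=O)c4cc(-c5ccccc5)ccn4)cc3F)ccnc2cc1OCCCN1CCCC1` is the reference of this small set. In a functional assay on MKN-45 cells (Homo sapiens) for cytotoxicity, read by MTT assay, with a stated time of 72 h (on this read-out higher numbers stand for weaker inhibition and lower numbers for stronger inhibition), compound 1 gives 210 nM. Compound 2 `COc1cc2c(Oc3ccc(NC(=O)c4cc(-c5ccccc5C)ccn4)cc3F)ccnc2cc1OCCCN1CCCC1` carries a single change against compound 1, namely (methyl in place of hydrogen on an aromatic carbon). In this assay compound 2 gives 440 nM, which is a 2.1-fold higher number from compound 1 to compound 2 (0.32 log units; beyond the scatter). Compound 3 `COc1cc2c(Oc3ccc(NC(=O)c4cc(-c5ccccc5)ccn4)cc3F)ccnc2cc1OCCCN1CCCCC1` differs from compound 1 in the basic amine at the end of the chain: piperidin-1-yl in place of pyrrolidin-1-yl on a saturated chain carbon, three bonds along the chain from an oxygen on an aromatic ring. In this assay compound 3 gives 270 nM, and the step of a 1.3-fold higher number from compound 1 to compound 3 (0.11 log units; within the scatter) leaves compound 1 and compound 3 indistinguishable on this read-out. Among the measured compounds shown here, no counted step links compound 2 and compound 3; their two values lie within the scatter of each other.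

Compound 4 `COc1cc2c(Oc3ccc(NC(=O)c4cc(-c5ccc(C)cc5)ccn4)cc3F)ccnc2cc1OCCCN1CCCCC1` has not yet been measured. It differs from compound 3 by methyl in place of hydrogen on an aromatic carbon. The same kind of change has been made once already, from compound 1 to compound 2, yet the place is not identical: in compound 2 the methyl sits ortho to a large group, whereas in compound 4 it sits para to a large group. For the measured compounds named here, the one measured instance, a 2.1-fold higher number from compound 1 to compound 2 (0.32 log units; beyond the scatter), is modest and only just beyond the scatter.

Resting on a 2.1-fold higher number from compound 1 to compound 2 (0.32 log units; beyond the scatter), and allowing that the place of the methyl differs, the step expected from compound 3 to compound 4 in this assay is a 1.7-fold higher number from compound 3 to compound 4 (0.22 log units; within the scatter). Compound 4 is therefore estimated at 450 nM, most likely between 220 nM and 950 nM.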

Compound 4, half-maximal inhibitory concentration: 1670 nM
Compound 4: middle estimate off by 3.7-fold (0.57 log units), on the low side, outside the stated range (above it).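

In this assay, methyl in place of hydrogen raises the number on both cores, and the new step is a 6.2-fold higher number from compound 3 to compound 4 (0.79 log units; beyond the scatter), so the direction carries over from the pyrrolidin-1-yl compounds to the piperidin-1-yl compounds. The size of the step does not carry over, as the two instances differ by more than repeated measurements would explain: the same change on two cores in this assay, a 2.1-fold higher number (0.32 log units; beyond the scatter) from compound 1 to compound 2 and a 6.2-fold higher number (0.79 log units; beyond the scatter) from compound 3 to compound 4, 3.0-fold (0.47 log units) apart, beyond the scatter of two such steps This does not show that the core alone sets the size of the step, since the two pairs differ in two ways at once: the amine at the end of the chain and the place of the methyl, which in compound 4 is para to a large group and in compound 2 is elsewhere on the phenyl ring, so with one pair of each kind the contribution of either difference cannot be separated.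

The compounds shown leave open how the 4-methylphenyl group would behave with pyrrolidin-1-yl at the end of the chain, and how the methyl placement of compound 2 would behave with piperidin-1-yl, the two pairings that would pull these differences apart. They also leave open whether a chlorine or a methoxy group at the place of the methyl in compound 4 would move the number in the same direction, and whether a morpholine at the end of the chain would change the picture.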